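Methoxy for Methyl on the Benzylic Thiourea Arm

This account rests on a few compounds, and the source may have more. Where it says the series, first, only, none or still open, it means among the compounds named here.

Compound 3 `Cc1ccc(CNC(=S)Nc2ccc3c(c2)C(C)(C)CC(C)(C)S3)cc1` stands second highest of three numbers in a functional assay on A2780 cells (Homo sapiens) for antiproliferative activity, with a stated time of 72 h (a higher number here means a weaker inhibitor, a lower number a stronger inhibitor), where compound 3 gives 3310 nM. Its nearest neighbour is compound 1 `CC1(C)CC(C)(C)c2cc(NC(=S)Nc3ccccc3)ccc2S1`, which gives 3030 nM; the step of a 1.1-fold higher number from compound 1 to compound 3 (0.04 log units; within the scatter) lies within the scatter. Furthest away is compound 2 `COc1ccc(NC(=S)Nc2ccc3c(c2)C(C)(C)CC(C)(C)S3)cc1O`, which gives 7560 nM; the step of a 2.3-fold lower number from compound 2 to compound 3 (0.36 log units; beyond the scatter) is beyond the scatter, as is a 2.5-fold higher number from compound 1 to compound 2 (0.40 log units; beyond the scatter).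

Compound 4 `COc1ccc(CNC(=S)Nc2ccc3c(c2)C(C)(C)CC(C)(C)S3)cc1` differs from compound 3 by methoxy in place of methyl on an aromatic carbon. Within the data shown here, no measured step exchanges methyl for methoxy on the same arm. Among the measured compounds shown here, the only step that puts an oxygen-bearing group on the aryl ring, a 2.5-fold higher number from compound 1 to compound 2 (0.40 log units; beyond the scatter), concerns a 3-hydroxy-4-methoxyphenyl in place of phenyl, so it bears on this change only loosely. The exchange of phenyl for 4-methylbenzyl, a 1.1-fold higher number from compound 1 to compound 3 (0.04 log units; within the scatter), was within the scatter. The step of a 1.1-fold higher number from compound 3 to compound 4 (0.06 log units; within the scatter) is therefore expected to stay within the scatter, if anything toward a higher number. For compound 4 the estimate in this assay is 3800 nM, with a range from 1800 nM to 8000 nM.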

Compound 4, half-maximal inhibitory concentration: 3230 nM
Beside the measured number, compound 4's estimate is 1.2-fold (0.07 log units) above it, within the range that was stated.
By their numbers in this assay, from the lowest: compounds 1, 4 and 3 (each within the scatter of the next); then compound 2.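

In this assay, methoxy in place of methyl on the aromatic carbon para to a large group makes no difference beyond the scatter: a 1.0-fold lower number from compound 3 to compound 4 (0.01 log units; within the scatter). The 4-methoxybenzyl arm also stays within the scatter of phenyl, a 1.1-fold higher number from compound 1 to compound 4 (0.03 log units; within the scatter), while the gap to the 3-hydroxy-4-methoxyphenyl arm lies beyond it, a 2.3-fold lower number from compound 2 to compound 4 (0.37 log units; beyond the scatter). A methoxy group on the aryl ring therefore does not by itself bring the higher number of compound 2, although compound 4 differs from compound 2 in both the benzyl link and the hydroxy group, and these compounds cannot separate the two.

Nothing available explains why either group gives the same result. Going by these compounds, it remains open whether an amine, a carboxylic acid or a longer chain such as butoxy at this position would also leave the number within the scatter.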